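The source may report more compounds than this note shows. Statements on the series, on what has been measured and on what is new or still open speak of the compounds shown alone.

In a functional assay on NCI-H1299 cells (Homo sapiens) for antiproliferative activity, read by XTT assay, with a stated time of 72 h (a higher number here means a weaker inhibitor, a lower number a stronger inhibitor), compound 2 `COc1ccc(-c2cc3ccccc3nc2/C=C/C(=O)c2ccco2)cc1` gives 730 nM, the lowest of the two numbers measured, while compound 1 `COc1ccc(-c2cc3ccccc3nc2/C=C/C(=O)c2ccc(N)cc2)cc1` gives 6510 nM. Within the data shown here, the only measured step, an 8.9-fold lower number from compound 1 to compound 2 (0.95 log units; beyond the scatter), swapped one ring on the carbonyl carbon for another and was modest. Compound 3 `COc1ccc(-c2cc3ccccc3nc2/C=C/C(=O)c2ccccn2)cc1` differs from compound 2 by pyridin-2-yl in place of furan-2-yl on a carbonyl carbon. Among the measured compounds shown here, since both rings here are small aromatic heterocycles, and the one measured step concerned a different exchange, the expectation is a step of a 1.4-fold higher number from compound 2 to compound 3 (0.14 log units; within the scatter), within or close to the scatter. Compound 3 is therefore estimated at 1000 nM, with a range from 300 nM to 3500 nM.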

Compound 3, half-maximal inhibitory concentration: 660 nM
Compound 3: middle estimate off by 1.5-fold (0.18 log units), on the high side, within the range that was stated.
By their numbers in this assay, from the lowest: compounds 3 and 2 (each within the scatter of the next); then compound 1.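

In this assay, a six-membered pyridin-2-yl ring on the carbonyl carbon does as well as the five-membered furan-2-yl ring, with a 1.1-fold lower number from compound 2 to compound 3 (0.04 log units; within the scatter), so for this pair neither ring size nor the swap of oxygen for nitrogen moves the number beyond the scatter. Pyridin-2-yl in place of 4-aminophenyl gives a 9.9-fold lower number from compound 1 to compound 3 (0.99 log units; beyond the scatter), so a second heteroaromatic ring also stands clearly apart from 4-aminophenyl. As far as these compounds go, whether an unsubstituted phenyl, a thiophen-2-yl or a pyridin-3-yl group on the carbonyl carbon would give a number like these stays open. No measurement shown gives a reason for these numbers.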